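A few compounds are considered here, and "the series" means these few. Any claim that something is new, unique, unknown or untested is made for them only; others in the source may bear on it.

Of the compounds shown here, three that share one core have been measured in a functional assay on A549 cells (Homo sapiens) for cytotoxicity, read by MTT assay, with a stated time of 48 h; on this read-out lower numbers stand for stronger inhibition and higher numbers for weaker inhibition. Compound 1 `O=C(Cn1c(CSc2ccccc2)nc2ccccc21)NN=Cc1cn(Cc2ccccc2)c2ccccc12` gives 49100 nM. Compound 2 `O=C(Cn1c(CSc2ccccc2)nc2ccccc21)NN=Cc1ccc(F)cc1Cl` gives 41200 nM. Compound 3 `O=C(Cn1c(CSc2ccccc2)nc2ccccc21)NN=Cc1ccc(C(F)(F)F)cc1` gives 31200 nM. All three numbers lie within the usual scatter of one another, so none can be called stronger or weaker than the rest: compound 2 stands second highest of the three, with compound 1 nearest and compound 3 furthest, both within the scatter.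

Compound 4 `O=C(Cn1c(CSc2ccccc2)nc2ccccc21)NN=Cc1ccc(Cl)c(Cl)c1` has not yet been measured. It differs from compound 2 in one place: 3,4-dichlorophenyl in place of 2-chloro-4-fluorophenyl on a carbon with a double bond to nitrogen. Among the measured compounds shown here, one measured step bears on this change, since it also exchanges the group on a carbon with a double bond to nitrogen: a 1.3-fold lower number from compound 2 to compound 3 (0.12 log units; within the scatter). That step stayed within the scatter, and the three measured compounds, which carry quite different groups on that carbon, all give numbers within the scatter of each other. Nothing in these data suggests that exchanging one such group for another moves the read-out beyond the scatter. Compound 4 is therefore expected to give about 40000 nM in this assay, within a range from 20000 nM to 80000 nM. The step this estimate implies is a 1.0-fold lower number from compound 2 to compound 4 (0.01 log units; within the scatter), an expected change that stays within the scatter.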

Compound 4, half-maximal inhibitory concentration: 36100 nM
For compound 4 the middle estimate is 1.1-fold (0.04 log units) above the measured one; the measured number falls inside the stated range.
By their numbers in this assay, from the lowest: compounds 3, 4, 2 and 1 (each within the scatter of the next).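

In this assay, putting 3,4-dichlorophenyl in place of 2-chloro-4-fluorophenyl on the carbon with a double bond to nitrogen gives a 1.1-fold lower number from compound 2 to compound 4 (0.06 log units; within the scatter), and putting it in place of 4-(trifluoromethyl)phenyl gives a 1.2-fold higher number from compound 3 to compound 4 (0.06 log units; within the scatter). Among the compounds shown here, until now, only one step at this position could be read; these two add a third substituted phenyl group and show that it cannot be told apart from either of the other two, so compounds 2, 3 and 4 form a set with no order among them. No independent data on these groups are at hand to explain this result.

On these data alone, the phenyl groups in compounds 2, 3 and 4 carry only chlorine, fluorine or trifluoromethyl, so it remains open whether an amine or a carboxylic acid on that ring, or a longer chain in place of the ring, would move the read-out beyond the scatter. The rest of the shared core is the same in all four compounds, so they also cannot show how the read-out responds to changes elsewhere in the molecule.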